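Swapping a piperazinyl for an acetyl(methyl)amino group

The source may report more compounds than this note shows. Statements on the series, on what has been measured and on what is new or still open speak of the compounds shown alone.

Among the measured compounds shown here, compound 2 `N#Cc1cc(NS(=O)(=O)c2ccc(N3CCNCC3)cc2)ccc1Oc1ccc(Cl)c(C(F)(F)F)c1` gives 68% in an assay for inhibition of platelet-activating factor acetylhydrolase (Rattus norvegicus), in plasma, with stated times of 30 min and 10 min, tested at 250 nM (a higher number here means more inhibition at the concentration tested (going by the name of the read-out), a lower number less inhibition), the highest of the two numbers measured so far. Its nearest neighbour is compound 1 `CC(=O)Nc1ccc(S(=O)(=O)Nc2ccc(Oc3ccc(Cl)c(C(F)(F)F)c3)c(C#N)c2)cc1`, which gives 64% in this assay, and the step of a number 4 percentage points higher from compound 1 to compound 2 (within the scatter) lies within the scatter, so the two cannot be ranked. Compound 3 `CC(=O)N(C)c1ccc(S(=O)(=O)Nc2ccc(Oc3ccc(Cl)c(C(F)(F)F)c3)c(C#N)c2)cc1` has not yet been measured. It differs from compound 2 in one place: acetyl(methyl)amino in place of piperazin-1-yl on an aromatic carbon. For the measured compounds named here, the group entering is the acetamido of compound 1 with a methyl in place of the amide hydrogen, so the one measured step bears on this change directly. That step, a number 4 percentage points higher from compound 1 to compound 2 (within the scatter), was small. The step of a number 6 percentage points lower from compound 2 to compound 3 (within the scatter) is therefore expected to stay within the scatter, with no clear direction. Compound 3 is estimated to give 62%, with a likely range from 45% to 78%.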

Compound 3, a percentage reported as inhibition, at one concentration (the size of the read-out at that concentration, not a potency): 45%
The estimate for compound 3 lay 17 percentage points above the measured number; the measured number falls inside the stated range.
By their numbers in this assay, from the lowest: compound 3; then compounds 1 and 2 (each within the scatter of the next).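

Compounds 1 and 2 could not be ranked, so the number was level for these two quite different groups at this position, para to a large group. That picture changes with a small edit: putting a methyl in place of the amide hydrogen gives a number 19 percentage points lower from compound 1 to compound 3 (beyond the scatter) in this assay, and acetyl(methyl)amino in place of piperazin-1-yl gives a number 23 percentage points lower from compound 2 to compound 3 (beyond the scatter), so the result here depends on the detail of the nitrogen attached to the ring. No available measurement explains why the methyl lowers the number.

The compounds shown cannot separate losing the amide hydrogen from adding the methyl. An ethyl on the same amide nitrogen, or a primary amine at this position, would show whether the trend extends beyond these three compounds.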